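Swapping Ethoxy for Diethylamino: What the Numbers Suggest

A few compounds are considered here, and "the series" means these few. Any claim that something is new, unique, unknown or untested is made for them only; others in the source may bear on it.

- compound 1 `COc1ccc(/C=C/c2cc(OC)cc(OC)c2/C=C/C(=O)c2ccc(Cl)c(Cl)c2)cc1` gives 10.8 ug/mL
- compound 2 `COc1ccc(/C=C/c2cc(OC)cc(OC)c2/C=C/C(=O)c2ccc(Br)cc2)cc1` gives 12.9 ug/mL
- compound 3 `CCOc1ccc(C(=O)/C=C/c2c(/C=C/c3ccc(OC)cc3)cc(OC)cc2OC)cc1` gives 8 ug/mL

All three values come from a functional assay on HepG2 cells (Homo sapiens) for antiproliferative activity, read by MTT assay, with a stated time of 48 h (on this read-out higher numbers stand for weaker inhibition and lower numbers for stronger inhibition), and share one core, differing only in the group on the aryl ring attached to the carbonyl. The number for compound 3 cannot be separated from the other two, since both of its gaps lie within the scatter of repeated measurements.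

Compound 4 `CCN(CC)c1ccc(C(=O)/C=C/c2c(/C=C/c3ccc(OC)cc3)cc(OC)cc2OC)cc1` has diethylamino in place of ethoxy on an aromatic carbon, para to a large group (diethylamino in place of ethoxy on an aromatic carbon). The closest evidence comes from changes of that same aryl group: a 1.4-fold lower number from compound 1 to compound 3 (0.13 log units; within the scatter), a 1.6-fold lower number from compound 2 to compound 3 (0.21 log units; within the scatter) and a 1.2-fold higher number from compound 1 to compound 2 (0.08 log units; within the scatter). Among the compounds with values here, each of these stayed within the scatter, though none of the measured compounds carries diethylamino, so the evidence is indirect. No step beyond the scatter is therefore expected in this assay, and no direction can be favoured. The expected step is a 1.1-fold higher number from compound 3 to compound 4 (0.05 log units; within the scatter). For compound 4 the estimated value is 9 ug/mL, with an expected range from 4 ug/mL to 20 ug/mL.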

Compound 4, half-maximal inhibitory concentration: 6.3 ug/mL
Compound 4: middle estimate off by 1.4-fold (0.15 log units), on the high side; the range from low to high includes it.
By their numbers in this assay, from the lowest: compounds 4, 3, 1 and 2 (each within the scatter of the next, the first and the last beyond it).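

In this assay, the position on the aromatic carbon para to a large group accepts diethylamino, with its 5 heavy atoms, in place of ethoxy, with its 3, giving a 1.3-fold lower number from compound 3 to compound 4 (0.10 log units; within the scatter) and so no separable change. Compound 4 also opens the first gap in this set to pass the scatter, seen in a 2.0-fold lower number from compound 2 to compound 4 (0.31 log units; beyond the scatter), a modest step, while a 1.7-fold lower number from compound 1 to compound 4 (0.23 log units; within the scatter) stays inside it, so the separation holds against the bromo compound alone. Nothing measured here accounts for these differences.

The compounds shown leave open how a primary amine, a morpholine ring or a carboxylic acid would read at this position. They also leave open whether a longer chain on the nitrogen would keep the number within the scatter of compound 4.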